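Enaminone series: bromophenyl in place of thiophene on the ketone

This account rests on a few compounds, and the source may have more. Where it says the series, first, only, none or still open, it means among the compounds named here.

The set holds three measured compounds. Compound 1 `O=C(C=CNc1cc(-c2ccccc2)nn1-c1ccccc1)c1cccs1` gives 15400 nM in a functional assay on MCF7 cells (Homo sapiens) for inhibition, read by MTT assay, with a stated time of 48 h; a higher number here means a weaker inhibitor, a lower number a stronger inhibitor. Compound 2 `c1ccc(-c2ccnc3c2c(-c2ccccc2)nn3-c2ccccc2)cc1` gives 28200 nM in this assay, and compound 3 `COc1ccc(-c2nc3c(c(-c4ccccc4)nn3-c3ccccc3)c(-c3ccc(N4CCN(C)CC4)cc3)c2C#N)cc1` gives 2650 nM in this assay. Among these three numbers compound 1 stands second highest; its gap to compound 2 lies within the scatter, so the two cannot be told apart, while compound 3 sits beyond the scatter at the lower end. Going by the values given here, no two of the three differ in one place only, so no single step between measured compounds is available to lean on.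

Compound 4 `O=C(C=CNc1cc(-c2ccccc2)nn1-c1ccccc1)c1ccc(Br)cc1` has not yet been measured in this assay. It differs from compound 1 as follows: 4-bromophenyl in place of thiophen-2-yl on a carbonyl carbon. With no measured step of this kind in the set, the expectation rests on compound 1 alone, and the change is expected to move the number by no more than the scatter, in either direction. Compound 4 is therefore expected at an estimated 15000 nM, with a range of 6000 nM to 40000 nM. The expected step of a 1.0-fold lower number from compound 1 to compound 4 (0.01 log units; within the scatter) is small.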

Compound 4, half-maximal inhibitory concentration: 21700 nM
The estimate for compound 4 lay 1.4-fold (0.16 log units) below the measured number, within the range that was stated.
By their numbers in this assay, from the lowest: compound 3; then compounds 1, 4 and 2 (each within the scatter of the next).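

Thiophen-2-yl on the carbonyl carbon can give way to 4-bromophenyl with no readable shift in this assay (a 1.4-fold higher number from compound 1 to compound 4 (0.15 log units; within the scatter)), so compound 1 and compound 4 cannot be told apart. This position therefore accepts a six-membered aromatic ring of carbon only, with 7 heavy atoms in place of 5 and no hydrogen-bond acceptor in the entering group, while the number stays within the scatter. No measurement on hand bears on why this exchange leaves the number unresolved.

As far as these compounds go, the contribution of the bromine remains open, since an unsubstituted phenyl on the same carbonyl carbon would separate it from that of the ring. Also open, from the compounds shown here alone, is whether a group of another kind, such as a dimethylamino group or a carboxylic acid in place of the bromine, would move the number beyond the scatter.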